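Swapping carboxy for hydroxy on the benzyl group

The compounds below may be only part of what the source reports. "The series", "measured", "known", "first", "only" and "open" are said of these compounds alone.

Values in a functional assay on KARPAS-299 cells (Homo sapiens) for cytotoxicity, read by XTT assay, with a stated time of 72 h; a higher number here means a weaker inhibitor, a lower number a stronger inhibitor:
Compound 1 `Cn1cc(-c2cnc3[nH]cc(-c4cnn(Cc5ccccc5)c4)c3c2)cn1` gives 3000 nM
Compound 2 `Cn1cc(-c2cnc3[nH]cc(-c4cnn(Cc5cccc(C#N)c5)c4)c3c2)cn1` gives 1610 nM
Compound 3 `Cn1cc(-c2cnc3[nH]cc(-c4cnn(Cc5cccc(C(=O)O)c5)c4)c3c2)cn1` gives > 10000 nM (a limit)

Compound 3 stands at the limit of > 10000 nM in this assay, at which 1 of the 3 values shown sits, so it is a limit and not a number. Compound 4 `Cn1cc(-c2cnc3[nH]cc(-c4cnn(Cc5cccc(O)c5)c4)c3c2)cn1` differs from it by hydroxy in place of carboxy on an aromatic carbon, which is hydroxy in place of carboxy on an aromatic carbon, or 3-carboxybenzyl to 3-hydroxybenzyl.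

Going by the values given here, no measured step tests hydroxy directly, so the nearest guides are the three changes at this same place. Placing carboxy on compound 1 gave an at least 3.3-fold higher number from compound 1 to compound 3 (0.52 log units; beyond the scatter), and replacing cyano with carboxy gave an at least 6.2-fold higher number from compound 2 to compound 3 (0.79 log units; beyond the scatter). By contrast, the step of a 1.9-fold lower number from compound 1 to compound 2 (0.27 log units; within the scatter) shows that cyano left the value of compound 1 essentially unchanged.

With carboxy gone, compound 4 is expected to return towards compound 1 and compound 2 in this assay, a modest move to a lower number. The expected change is an at least 4.0-fold lower number from compound 3 to compound 4 (0.60 log units; beyond the scatter). For compound 4 the estimated value is 2500 nM, with an expected range from 900 nM to 7500 nM.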

Compound 4, half-maximal inhibitory concentration: 3360 nM
For compound 4 the middle estimate is 1.3-fold (0.13 log units) below the measured one; the range from low to high includes it.
By their numbers in this assay, from the lowest: compounds 2, 1 and 4 (each within the scatter of the next, the first and the last beyond it). At a limit, above all of these: compound 3.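

Compound 3 is held at a limit and not a number: the limit of > 10000 nM in this assay, at which 1 of the 4 values shown sits.

Even so, in this assay the change from 3-carboxybenzyl to 3-hydroxybenzyl reads as an at least 2.9-fold lower number from compound 3 to compound 4 (0.47 log units; beyond the scatter), so the loss seen with carboxy does not extend to every group at this place that counts one hydrogen-bond donor and one hydrogen-bond acceptor. Set against hydrogen, the step is a 1.1-fold higher number from compound 1 to compound 4 (0.05 log units; within the scatter), whereas against cyano it is a 2.1-fold higher number from compound 2 to compound 4 (0.32 log units; beyond the scatter), though compound 1 and compound 2 stand within the scatter of each other.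

The compounds shown leave open whether an amine or a carboxamide at this place would go with carboxy or with hydroxy. Since all of them carry their group at this one place, they also cannot tell how the same groups would behave elsewhere on the ring.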